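Series notes: from compound 2 to compound 3

The source may report more compounds than this note shows. Statements on the series, on what has been measured and on what is new or still open speak of the compounds shown alone.

Measured so far in an in vitro functional assay on HEK293S cells with Glucose-dependent insulinotropic receptor (Homo sapiens) as the target, read by HTRF and cAMP accumulation, with a stated time of 45 min; on this read-out higher numbers stand for larger maximal responses and lower numbers for smaller maximal responses:
Compound 1, `C[C@@H]1CN(C(=O)OC(C)(C)C)C[C@H](C)N1c1ncc(OCc2ccc(S(C)(=O)=O)cc2)cn1`, gives 104%.
Compound 2, `Cc1cc(COc2cnc(N3CCN(C(=O)OC(C)(C)C)CC3)nc2)ccn1`, gives 19%.

Compound 2 stands lowest of the two numbers. Its nearest neighbour is compound 1, whose value lies higher by a gap beyond the usual scatter. The two compounds differ in more than one place, so nothing is said here about a single step between them; only the two values themselves are known.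

Compound 3, `COc1cnccc1COc1cnc(N2CCN(C(=O)OC(C)(C)C)CC2)nc1`, differs from compound 2 in one place:
3-methoxypyridin-4-yl in place of 2-methylpyridin-4-yl on a saturated chain carbon bound to an oxygen on an aromatic ring

Going by the values given here, no step of this kind has been measured in this assay. The step from compound 2 to compound 3, a number 11 percentage points higher from compound 2 to compound 3 (beyond the scatter), is expected to be small, with its direction uncertain and possibly not beyond the scatter. Compound 3 is therefore estimated at 30%, with a range from 5% to 75%.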

Compound 3, intrinsic activity: the largest response reached, in percent of the reference agonist's in the Glucose-dependent insulinotropic receptor assay: 22%
For compound 3 the middle estimate is 8 percentage points above the measured one; measured number inside the range.
By their numbers in the Glucose-dependent insulinotropic receptor assay, from the lowest: compounds 2 and 3 (each within the scatter of the next); then compound 1.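

In the Glucose-dependent insulinotropic receptor assay, the first step measured at this position, 3-methoxypyridin-4-yl in place of 2-methylpyridin-4-yl on a saturated chain carbon bound to an oxygen on an aromatic ring gives a number 3 percentage points higher from compound 2 to compound 3 (within the scatter), so this change does not separate the two compounds on maximal response. In a physicochemical assay for lipophilicity, using the shake flask method, in phosphate buffer, measured as octanol-water partition, at pH 7.4 (a lower number here means a more polar compound, a higher number a more lipophilic compound), compound 2 gives 3.7 and compound 3 gives 3.8, and these two values do not separate the compounds either. Nothing available here accounts for this outcome.

Still open, on these data alone, is whether a carboxylic acid or an amine in place of the methoxy group would give a value apart from compound 3 in the Glucose-dependent insulinotropic receptor assay. Going by these compounds alone, also open is whether the same swap would read alike on the core of compound 1 , since only this one pair carries it.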